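The source may hold more compounds than are shown below. What is called first, only, known or untested is meant among the compounds shown, and "the series" means these compounds.

The measured compounds:
compound 1, `COC(=O)C1=C(C)NC(=O)NC1c1cccs1`, 3%
compound 2, `COC(=O)C1=C(C)N(C)C(=O)NC1c1ccco1`, 9%
compound 3, `COC(=O)C1=C(C)N(C)C(=O)NC1c1ccoc1`, 7%

All three were tested in an assay on membranes from HeLa cells for displacement of a labelled ligand from adenosine receptor A3 (Homo sapiens), read by scintillation counting, with a stated time of 180 min, tested at 1 uM; a higher number here means more inhibition at the concentration tested (going by the name of the read-out), a lower number less inhibition. Compound 3 gives 7%, which places it second highest of the three numbers. Its nearest neighbour is compound 2 at 9%, and the furthest is compound 1 at 3%. Both gaps lie within the usual scatter of this kind of measurement, so the three numbers are best read as equally low, with only a small part of the labelled ligand displaced at the concentration used.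

Compound 4, `COC(=O)C1=C(C)N(C)C(=O)NC1c1cccs1`, has not yet been measured. It differs from compound 3 in one place: thiophen-2-yl in place of furan-3-yl on a saturated ring carbon. Within the data shown here, the only measured step that changes the group on this saturated ring carbon is the one from compound 2 to compound 3, where a number 2 percentage points lower from compound 2 to compound 3 (within the scatter). That swap between two furan groups left the number essentially unchanged. Compound 1, which differs elsewhere but carries the same thiophen-2-yl group, gives 3%, again a low number. On this basis no step beyond the scatter is expected in this assay. The expected step is a number 2 percentage points lower from compound 3 to compound 4 (within the scatter). Compound 4 is therefore estimated to give 5%, with a range from -5% to 15%.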

Compound 4, a percentage reported as inhibition, at one concentration (the size of the read-out at that concentration, not a potency): 15%
For compound 4 the middle estimate is 10 percentage points below the measured one; the range from low to high includes it.
By their numbers in this assay, from the lowest: compounds 1, 3, 2 and 4 (each within the scatter of the next, the first and the last beyond it).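

Swapping either furan group for thiophen-2-yl on the saturated ring carbon gives a number 8 percentage points higher from compound 3 to compound 4 (within the scatter) and a number 6 percentage points higher from compound 2 to compound 4 (within the scatter) in this assay, so these three five-membered aromatic rings with one hetero atom cannot be told apart at this position, even with the sulfur atom taking the place of oxygen. Among these compounds, the new information comes from elsewhere in the molecule: with thiophen-2-yl held constant, methyl in place of hydrogen on the amide-type nitrogen in the ring gives a number 12 percentage points higher from compound 1 to compound 4 (beyond the scatter), the first step in this set to lie beyond the usual scatter, though it is modest in size. No measurement is available that would explain this step.

From the compounds shown here alone, that nitrogen step rests on a single pair of compounds, so it remains open whether the same change would give a similar step with a furan group on the saturated ring carbon, or whether an ethyl group on the nitrogen would go further. Going by these compounds, it is also open how a quite different group on the saturated ring carbon, such as a phenyl ring, a propyl chain or a group carrying an amine, would read in this assay.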